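A Methoxycarbonyl Onto the Chain Carbon of Compound 2

This account rests on a few compounds, and the source may have more. Where it says the series, first, only, none or still open, it means among the compounds named here.

Compound 1 `Cn1c(=O)c(S(=O)(=O)c2ccc(F)cc2F)cc2cnc(Nc3ccc4cc[nH]c4c3)nc21` gives 5000 nM in a functional assay on K562 cells (Homo sapiens) for inhibition, read by trypan blue exclusion, with a stated time of 72 h; a lower number here means a stronger inhibitor, a higher number a weaker inhibitor. Compound 2 `Cn1ccc2cc(Nc3ncc4cc(S(=O)(=O)c5ccc(F)cc5F)c(=O)n(C)c4n3)ccc21` gives 750 nM in this assay, the lowest of the two numbers seen so far, and the step of a 6.7-fold lower number from compound 1 to compound 2 (0.82 log units; beyond the scatter) is the only measured one. Compound 3 `COC(=O)Cn1ccc2cc(Nc3ncc4cc(S(=O)(=O)c5ccc(F)cc5F)c(=O)n(C)c4n3)ccc21` differs from compound 2 by methoxycarbonyl in place of hydrogen on a saturated chain carbon bound to an aromatic nitrogen. Among the measured compounds shown here, no measured step bears on this change; the single measured step concerns a different part of the molecule, so no shift beyond the scatter is expected in either direction. Compound 3 is therefore expected to move only a 1.3-fold higher number from compound 2 to compound 3 (0.12 log units; within the scatter), landing at an estimated 1000 nM with a range from 300 nM to 3500 nM.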

Compound 3, half-maximal inhibitory concentration: 5000 nM
For compound 3 the middle estimate is 5.0-fold (0.70 log units) below the measured one, outside the stated range (above it).
By their numbers in this assay, from the lowest: compound 2; then compounds 1 and 3 (each within the scatter of the next).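

In this assay, the chain carbon bound to the aromatic nitrogen proves sensitive to substitution: methoxycarbonyl in place of hydrogen gives a 6.7-fold higher number from compound 2 to compound 3 (0.82 log units; beyond the scatter). The earlier step did not test this carbon, and it now shows that going from methyl to (methoxycarbonyl)methyl here costs inhibition of the cells. No measurement shown explains this loss.

Going by these compounds, it remains open whether a carboxylic acid, an amine or a plain longer chain on this same carbon would stay close to compound 2 or shift the number as methoxycarbonyl did.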